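A few compounds are considered here, and "the series" means these few. Any claim that something is new, unique, unknown or untested is made for them only; others in the source may bear on it.

Working notes on the series. Compound 1 `Oc1ccccc1/C=N/c1sc2c(c1-c1nc3ccccc3s1)CCC2` and compound 2 `Fc1ccc(/C=N/c2sc3c(c2-c2nc4ccccc4s2)CCCC3)cc1` were both run in an ADME assay on cells (Rhabdomyosarcoma cell, Homo sapiens) for cytotoxicity, read by MTT assay, with a stated time of 72 h; on this read-out higher numbers stand for lower toxicity in this test and lower numbers for higher toxicity in this test. In this assay compound 1 gives 100 ug/mL. In this assay, within the data shown here, compound 2 gives 230 ug/mL, the higher of the two numbers, and the gap between compound 2 and compound 1 lies beyond the scatter; these two differ in more than one place, so no single step connects them. Compound 3 `O=[N+]([O-])c1ccccc1/C=N/c1sc2c(c1-c1nc3ccccc3s1)CCCC2` has not yet been measured in this assay. It differs from compound 2 by one change: 2-nitrophenyl in place of 4-fluorophenyl on a carbon with a double bond to nitrogen. Among the measured compounds shown here, no measured pair isolates a change of this kind, so the direction is open. From the two numbers in hand the expectation for compound 3 in this assay is a value near the middle of the range they span, with the step of a 1.5-fold lower number from compound 2 to compound 3 (0.19 log units; within the scatter) from compound 2 expected to stay within or just beyond the scatter. The estimate for compound 3 in this assay is 150 ug/mL, expected between 60 ug/mL and 320 ug/mL.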

Compound 3, half-maximal cytotoxic concentration: 255 ug/mL
Compound 3: the middle estimate sits 1.7-fold (0.23 log units) below what was measured; the measured number falls inside the stated range.
By their numbers in this assay, from the lowest: compound 1; then compounds 2 and 3 (each within the scatter of the next).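

Among these compounds, this is the first comparison that isolates a single place: on the carbon with a double bond to nitrogen, 2-nitrophenyl in place of 4-fluorophenyl gives a 1.1-fold higher number from compound 2 to compound 3 (0.04 log units; within the scatter) in this assay. At this position, the read-out does not separate these two aryl groups, even though the entering group brings a nitro group and the leaving group a fluorine. No measurement at hand accounts for this result.

Compound 1 differs from compound 2 and compound 3 in more than one place, so the source of its lower number stays unassigned. Also open, as far as these compounds go, is whether a group of another kind at this carbon, such as an aminophenyl or a carboxylic acid on the ring, would stay within the scatter of compound 2.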